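Methoxy to fluoro on the pendant phenyl of compound 3

The source may hold more compounds than are shown below. What is called first, only, known or untested is meant among the compounds shown, and "the series" means these compounds.

In a functional assay on MCF7 cells (Homo sapiens) for antiproliferative activity, read by sulforhodamine B assay, with a stated time of 48 h (a lower number here means a stronger inhibitor of growth, a higher number a weaker inhibitor of growth), three compounds have been measured:

Compound 1 `Cc1ccc(-c2cc(N3CCC(CNS(N)(=O)=O)CC3)ncn2)cc1` gives 30600 nM.
Compound 2 `COc1ccc(-c2cc(N3CCC(CNS(N)(=O)=O)CC3)ncn2)cc1` gives 35300 nM.
Compound 3 `COc1ccccc1-c1cc(N2CCC(CNS(N)(=O)=O)CC2)ncn1` gives 10100 nM.

Compound 3 gives the lowest number of the three, with compound 1 nearest (a 3.0-fold lower number from compound 1 to compound 3 (0.48 log units; beyond the scatter)) and compound 2 furthest (a 3.5-fold lower number from compound 2 to compound 3 (0.54 log units; beyond the scatter)). Both of those steps move the same pendant group from one position on the phenyl ring to another, and both lie beyond the scatter, so the position of the substituent appears to matter more than its identity among these compounds.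

Compound 4 `NS(=O)(=O)NCC1CCN(c2cc(-c3ccccc3F)ncn2)CC1` keeps that position but replaces the group there: fluoro in place of methoxy on an aromatic carbon. Going by the values given here, no measured step swaps these two groups at this position. The closest comparison is a 1.2-fold higher number from compound 1 to compound 2 (0.06 log units; within the scatter), a swap between two small groups at the other position, which stays within the scatter. On that basis the step from compound 3 to compound 4 in this assay is expected to be small, and the estimate is a 1.1-fold higher number from compound 3 to compound 4 (0.04 log units; within the scatter), with no strong expectation of direction. Compound 4 is therefore expected to give about 11000 nM, within a range of 4000 nM to 30000 nM.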

Compound 4, concentration for 50% growth inhibition: 48500 nM
Beside the measured number, compound 4's estimate is 4.4-fold (0.64 log units) below it, outside the stated range (above it).
By their numbers in this assay, from the lowest: compound 3; then compounds 1, 2 and 4 (each within the scatter of the next).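

The earlier compounds shown here suggested that the position of the substituent on the phenyl ring counted for more than its identity, but this result shows that identity counts too: in this assay, with the position held, fluoro in place of methoxy gives a 4.8-fold higher number from compound 3 to compound 4 (0.68 log units; beyond the scatter), the largest step seen so far in this small set. A substituent at this place is therefore not enough by itself to give the lower number, as the 2-fluorophenyl compound shows a 1.4-fold higher number from compound 2 to compound 4 (0.14 log units; within the scatter) and a 1.6-fold higher number from compound 1 to compound 4 (0.20 log units; within the scatter), so among these four only the 2-methoxyphenyl group stands apart. Nothing available here explains why methoxy and fluoro differ at this place.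

The compounds shown leave open whether the lower number belongs to methoxy alone or would also appear with another group at this place, such as ethoxy, hydroxyl or an amine. Going by these compounds alone, they also leave open whether a 4-fluorophenyl group would give a number in line with compound 1 and compound 2, which would show whether fluoro matters at only one place on the ring.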